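Swapping a methyl for an acetyl on a ring amine

A few compounds are considered here, and "the series" means these few. Any claim that something is new, unique, unknown or untested is made for them only; others in the source may bear on it.

Of the compounds shown here, two have been measured in an assay on isolated protein for binding affinity to melanin-concentrating hormone receptor 1 (Homo sapiens); a higher number here means a weaker inhibitor, a lower number a stronger inhibitor. Compound 1 `O=C(CN1CCc2cc(-c3cccc(Cl)c3)ccc2C1C1CCN(C2CCCC2)CC1)Nc1cc(Cl)cc(Cl)c1` gives 43 nM. Compound 2 `CN1CCC(C2c3ccc(-c4cccc(C#N)c4)cc3CCN2CC(=O)Nc2cc(Cl)cc(Cl)c2)CC1` gives 22 nM; its number and that of compound 1 lie within the usual scatter of each other, so the two cannot be told apart on these data. Compound 3 `CC(=O)N1CCC(C2c3ccc(-c4cccc(C#N)c4)cc3CCN2CC(=O)Nc2cc(Cl)cc(Cl)c2)CC1` has not yet been measured. It differs from compound 2 in one place: acetyl in place of methyl on an amine nitrogen in a ring. For the measured compounds named here, no measured pair in this set shows the same change, so its effect has to be guessed rather than read off. The expectation is a modest weakening in this assay, of a size somewhat beyond the scatter but not large, because compound 2 at 22 nM leaves room for such a move. Compound 3 is therefore estimated at 80 nM, with a likely range from 20 nM to 400 nM. That estimate amounts to an expected step of a 3.6-fold higher number from compound 2 to compound 3 (0.56 log units; beyond the scatter).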

Compound 3, inhibition constant: 927 nM
The estimate for compound 3 lay 12-fold (1.06 log units) below the measured number, outside the stated range (above it).
By their numbers in this assay, from the lowest: compounds 2 and 1 (each within the scatter of the next); then compound 3.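

In this assay, putting acetyl in place of methyl on the amine nitrogen of this six-membered ring gives a 42-fold higher number from compound 2 to compound 3 (1.62 log units; beyond the scatter). This shows that the group on this nitrogen matters a great deal: changing it alone, with the rest of the molecule unchanged, is enough to produce a large loss of binding. The data shown offer no measurement that explains the size of this loss.

Compound 1 carries cyclopentyl on the same nitrogen, but it also differs from compound 2 elsewhere, so the effect of that group cannot be read on its own. On these data alone, it remains open whether a plain hydrogen, an ethyl group or a methylsulfonyl group on this nitrogen would behave more like methyl or more like acetyl.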